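Working notes: from compound 1 to compound 4

The compounds below may be only part of what the source reports. "The series", "measured", "known", "first", "only" and "open" are said of these compounds alone.

Measured so far in a functional assay on SiHa cells (Homo sapiens) for inhibition, read by sulforhodamine B assay; on this read-out lower numbers stand for stronger inhibition of growth and higher numbers for weaker inhibition of growth
- compound 1 `Cc1ccc2[nH]c(-c3ccc(-c4ccc(-c5cccc(Cl)c5)cc4)cc3)nc2c1` gives 3600 nM
- compound 2 `COc1cc(-c2ccc(-c3ccc(-c4nc5cc(C)ccc5[nH]4)cc3)cc2)cc(OC)c1OC` gives 170 nM
- compound 3 `Clc1cccc(-c2ccc(-c3ccc(-c4nc5ccccc5[nH]4)cc3)cc2)c1` gives 100000 nM

Not yet measured: compound 4 `Cc1ccc2[nH]c(-c3ccc(-c4ccc(-c5ccc(F)cc5)cc4)cc3)nc2c1`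

Compound 1 holds the middle of the three numbers, with compound 2 lower and compound 3 higher. Compound 4 differs from it by 4-fluorophenyl in place of 3-chlorophenyl on an aromatic carbon (4-fluorophenyl in place of 3-chlorophenyl on an aromatic carbon, para to a large group). Among the compounds with values here, no measured step covers this exchange. The only one available, a 28-fold higher number from compound 1 to compound 3 (1.44 log units; beyond the scatter) (hydrogen in place of methyl on an aromatic carbon), is large but lies at another place, and compound 4 keeps the methyl. Compound 2 carries a different group at the changing place and shows a lower number than compound 1, so a shift cannot be excluded. The expected outcome in this assay is a 1.2-fold lower number from compound 1 to compound 4 (0.08 log units; within the scatter) with no firm direction and no step beyond the scatter foreseen. In this assay compound 4 is estimated at 3000 nM with an expected range of 600 nM to 15000 nM for now.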

Compound 4, concentration for 50% growth inhibition: 41000 nM
Beside the measured number, compound 4's estimate is 14-fold (1.14 log units) below it, and the stated range ends below it.
By their numbers in this assay, from the lowest: compound 2; then compound 1; then compound 4; then compound 3.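

In this assay, within the data shown here, 4-fluorophenyl in place of 3-chlorophenyl gives an 11-fold higher number from compound 1 to compound 4 (1.06 log units; beyond the scatter), the first measured step at this place. Growth inhibition here therefore depends on the group at this place, even though the leaving and entering groups have the same heavy-atom count. The halogen and its ring position change together, so the step cannot be assigned to either one alone. No measurement available here accounts for the step. Still open, on these data alone, is how an amine or a carboxylic acid on this phenyl would read out.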